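Working notes: acetyl in place of cyclobutyl

The compounds below may be only part of what the source reports. "The series", "measured", "known", "first", "only" and "open" are said of these compounds alone.

Measured in a functional assay on NCI-H1581 cells (Homo sapiens) for antiproliferative activity, read by CCK-8 assay, with a stated time of 72 h; a lower number here means a stronger inhibitor, a higher number a weaker inhibitor:
- compound 1 `COc1cc(OC)c(Cl)c(-c2ccc3c(NC(=O)c4ccc(N5CCN(C(C)C)CC5)cc4)n[nH]c3n2)c1Cl` gives 1.4 nM
- compound 2 `COc1cc(OC)c(Cl)c(-c2ccc3c(NC(=O)c4ccc(N5CCN(C6CCC6)CC5)cc4)n[nH]c3n2)c1Cl` gives 2.3 nM

Compound 2 cannot be told apart from compound 1 on these numbers, as the two values lie within the scatter of each other. The next structure is compound 3 `COc1cc(OC)c(Cl)c(-c2ccc3c(NC(=O)c4ccc(N5CCN(C(C)=O)CC5)cc4)n[nH]c3n2)c1Cl`, not yet measured in this assay. It carries acetyl in place of cyclobutyl on an amine nitrogen in a ring.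

Within the data shown here, only one measured step bears on this change: a 1.6-fold higher number from compound 1 to compound 2 (0.22 log units; within the scatter). That step stayed on the same nitrogen but exchanged isopropyl for cyclobutyl, and neither of those groups has the hydrogen-bond acceptor that acetyl brings. Among the measured compounds shown here, it therefore shows tolerance only among groups without that acceptor, and no measured compound has acetyl at this place. A move beyond the scatter towards a higher number is expected, with low confidence in its size. The expected step is a 3.0-fold higher number from compound 2 to compound 3 (0.48 log units; beyond the scatter). The estimated value for compound 3 is 7 nM, with an expected range of 2 nM to 30 nM.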

Compound 3, half-maximal inhibitory concentration: 43.3 nM
Compound 3: the middle estimate sits 6.2-fold (0.79 log units) below what was measured, and the stated range ends below it.
By their numbers in this assay, from the lowest: compounds 1 and 2 (each within the scatter of the next); then compound 3.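

At this amine nitrogen in a ring, the group carried does matter in this assay: acetyl in place of cyclobutyl gives a 19-fold higher number from compound 2 to compound 3 (1.27 log units; beyond the scatter) and acetyl in place of isopropyl gives a 31-fold higher number from compound 1 to compound 3 (1.49 log units; beyond the scatter), both large and beyond the scatter. The lack of a readable difference between compound 1 and compound 2 therefore holds for that pair only and does not extend to acetyl, so this position cannot be treated as open to any group. Acetyl differs from cyclobutyl in several counted features at once, namely its oxygen, its hydrogen-bond acceptor, its double bond outside aromatic rings and the absence of a ring, and nothing available shows which of these, if any, accounts for the step.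

The three compounds shown cannot separate the carbonyl from the other differences, since every group here other than acetyl is a plain carbon substituent. A methyl group or a 2-hydroxyethyl chain on this nitrogen, or a methanesulfonyl or oxetanyl group in place of acetyl, would show whether the high number follows the carbonyl itself or extends to other oxygen-bearing groups.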